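This account rests on a few compounds, and the source may have more. Where it says the series, first, only, none or still open, it means among the compounds named here.

Of the compounds shown here, three sharing one core have been measured in a functional assay on GLC82 cells (Homo sapiens) for cytotoxicity, read by MTT assay, with a stated time of 72 h; a lower number here means a stronger inhibitor, a higher number a weaker inhibitor. Compound 1 `O=C(NC(=S)NNc1ncnc2ccccc12)c1ccc(C(F)(F)F)cc1` gives 12200 nM. Compound 2 `O=C(NC(=S)NNc1ncnc2ccccc12)c1ccc(Cl)cc1` gives 6680 nM, and compound 3 `COc1cc2ncnc(NNC(=S)NC(=O)c3ccc(C)cc3)c2cc1OC`, which differs from the other two in several places, gives 29900 nM. Compound 2 has the lowest number of the three: the step of a 1.8-fold lower number from compound 1 to compound 2 (0.26 log units; within the scatter) is within the scatter, while the gap to compound 3 lies beyond it. The unmeasured compound 4 `O=C(NC(=S)NNc1ncnc2ccccc12)c1ccccc1F` differs from compound 2 in one place: 2-fluorophenyl in place of 4-chlorophenyl on a carbonyl carbon. The only measured single step, that from compound 1 to compound 2, exchanges one group for another on the same aromatic carbon and stays within the scatter; no measured step exchanges a 4-chlorophenyl for a 2-fluorophenyl, so the bearing of that change on this assay is not shown by the data. The step of a 1.3-fold higher number from compound 2 to compound 4 (0.13 log units; within the scatter) is therefore expected to stay within the scatter. Compound 4 is estimated to give 9000 nM in this assay, within a range from 4000 nM to 20000 nM.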

Compound 4, half-maximal inhibitory concentration: 6460 nM
Estimate against measurement, compound 4: 1.4-fold (0.14 log units) above, within the range that was stated.
By their numbers in this assay, from the lowest: compounds 4, 2 and 1 (each within the scatter of the next); then compound 3.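

In this assay, 2-fluorophenyl in place of 4-chlorophenyl on a carbonyl carbon gives a 1.0-fold lower number from compound 2 to compound 4 (0.01 log units; within the scatter), so a change of the whole aryl group here, not only of one substituent on an aromatic carbon, also stays within the scatter. Read with a 1.8-fold lower number from compound 1 to compound 2 (0.26 log units; within the scatter), this means that both single exchanges shown on the aromatic group held by this carbonyl carbon stay within the scatter, although the groups differ in their halogen and in the numbering of their names. Nothing available accounts for this result.

Going by these compounds, whether an amine or a carboxylic acid on this aromatic ring, or an alkyl chain in place of the ring, would also stay within the scatter remains open. So does the bearing of the methoxy groups of compound 3, which differs from the others in several places.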